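The source may report more compounds than this note shows. Statements on the series, on what has been measured and on what is new or still open speak of the compounds shown alone.

Compound 1 `Cc1ccc(S(=O)(=O)c2cnc3ccc(Cl)cc3c2N2CCC(C)CC2)cc1C` — 84%
Compound 2 `CC1CCN(c2c(S(=O)(=O)c3ccc(Cl)c(Cl)c3)cnc3ccc(Cl)cc23)CC1` — 86%
Compound 3 `CC1CCN(c2c(S(=O)(=O)c3cccc(F)c3)cnc3ccc(Cl)cc23)CC1` — 58%

In an assay on isolated protein for displacement of a labelled ligand from metabotropic glutamate receptor 5 (Homo sapiens), with a stated time of 60 min, tested at 1 uM (a lower number here means less inhibition, a higher number more inhibition at the concentration tested (going by the name of the read-out)), compound 3 stands lowest of the three numbers. The steps towards it were both beyond the scatter: a number 26 percentage points lower from compound 1 to compound 3 (beyond the scatter) and a number 28 percentage points lower from compound 2 to compound 3 (beyond the scatter). Compound 1 and compound 2, by contrast, lie within the scatter of each other, with a step of a number 2 percentage points higher from compound 1 to compound 2 (within the scatter).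

Compound 4 `CC1CCN(c2c(S(=O)(=O)c3ccc(C#N)cc3)cnc3ccc(Cl)cc23)CC1` has not yet been measured in this assay. It differs from compound 3 in one place: 4-cyanophenyl in place of 3-fluorophenyl on a sulfonyl sulfur. The two measured steps that bear on this change are those in which the 3-fluorophenyl ring was exchanged, and both were modest and in the same direction. Going by the values given here, no measured step involves a 4-cyanophenyl ring, so the direction for compound 4 rests on the observation that the 3-fluorophenyl compound gave the lowest number. A modest rise is therefore expected, estimated as a number 8 percentage points higher from compound 3 to compound 4 (within the scatter), though a change within the scatter cannot be excluded. For compound 4 the estimate in this assay is 66%, with a range from 42% to 88%.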

Compound 4, a percentage reported as inhibition, at one concentration (the size of the read-out at that concentration, not a potency): 31%
Compound 4: middle estimate off by 35 percentage points, on the high side, outside the stated range (below it).
By their numbers in this assay, from the lowest: compound 4; then compound 3; then compounds 1 and 2 (each within the scatter of the next).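

In this assay, exchanging 3-fluorophenyl for 4-cyanophenyl on the sulfonyl sulfur gives a number 27 percentage points lower from compound 3 to compound 4 (beyond the scatter), so among the compounds shown the 3-fluorophenyl ring does not mark the lowest number at this position. Measured against the two other rings, the same position gives a number 55 percentage points lower from compound 2 to compound 4 (beyond the scatter) and a number 53 percentage points lower from compound 1 to compound 4 (beyond the scatter), which shows how widely the number can move at this one place while the rest of the molecule stays the same. Nothing available accounts for the drop seen with this change.

The compounds shown leave open whether the nitrile itself or its place on the ring sets the number: 4-cyanophenyl differs from 3-fluorophenyl in both. A 3-cyanophenyl or a 4-fluorophenyl ring on the sulfonyl sulfur would separate the two.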